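The source may report more compounds than this note shows. Statements on the series, on what has been measured and on what is new or still open speak of the compounds shown alone.

Compound 2, `COc1ccc(CNc2cc(OC)c(OC)c(OC)c2)cc1`, is the shared scaffold from which the new analogue departs. In a functional assay on MGC-803 cells (Homo sapiens) for inhibition, read by MTT assay, with a stated time of 48 h (a higher number here means a weaker inhibitor, a lower number a stronger inhibitor), compound 2 gives 11400 nM, the higher of the two numbers recorded. Compound 1, `COc1ccc(CN(C(=O)C2CC2)c2cc(OC)c(OC)c(OC)c2)cc1O`, carries a cyclopropanecarbonyl group on its nitrogen and a hydroxyl on the second ring, and in this assay compound 1 gives 59 nM; these two compounds differ in more than one place, so their values are set side by side without a single step between them. Compound 3, `COc1cc(NCc2ccccc2)cc(OC)c1OC`, lacks the methoxy group altogether, and in this assay compound 3 reaches only a limit, > 80000 nM. Taken as a step, removing that methoxy gives an at least 7.0-fold higher number from compound 2 to compound 3 (0.84 log units; beyond the scatter), which shows the substituent pattern on that ring matters.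

Compound 4, `COc1ccc(CNc2cc(OC)c(OC)c(OC)c2)cc1N`, is the compound not yet measured. It differs from compound 2 by amino in place of hydrogen on an aromatic carbon. Within the data shown here, no measured step adds an amino group, so the only bearing evidence is the loss of potency seen in an at least 7.0-fold higher number from compound 2 to compound 3 (0.84 log units; beyond the scatter) when the neighbouring ring is stripped, and compound 1 with its hydroxyl at the same place at 59 nM, which is confounded by its amide. A modest gain, or none beyond the scatter, is therefore expected, estimated as a 2.3-fold lower number from compound 2 to compound 4 (0.36 log units; beyond the scatter). Compound 4 is expected at 5000 nM, within 1500 nM to 20000 nM.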

Compound 4, half-maximal inhibitory concentration: 7970 nM
Estimate against measurement, compound 4: 1.6-fold (0.20 log units) below; measured number inside the range.
By their numbers in this assay, from the lowest: compound 1; then compounds 4 and 2 (each within the scatter of the next). At a limit, above all of these: compound 3.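

With an amino group in place of hydrogen on the aromatic carbon ortho to a methoxy group, compound 4 gives the first single-place change shown at this position, a 1.4-fold lower number from compound 2 to compound 4 (0.16 log units; within the scatter) in this assay. This step lies within the scatter, so this position takes an amino group, with its hydrogen-bond donor and acceptor, without any measurable shift in this assay, whereas the loss of the methoxy group on the same ring lies beyond the scatter (an at least 7.0-fold higher number from compound 2 to compound 3 (0.84 log units; beyond the scatter)). That second step has no fixed size, as compound 3 stands only at a limit and not at a number: the limit of > 80000 nM in this assay, at which 1 of the 4 values shown sits.

The compounds shown leave open whether a different group at this position, such as a carboxylic acid, a nitrile or a longer chain, would move the number beyond the scatter. Among these compounds, they also do not separate the contributions of the hydroxyl and the cyclopropanecarbonyl group in compound 1, which gives 59 nM, as no single-place step isolates either group.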